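From methoxy to hydroxy on a shared core

The compounds below may be only part of what the source reports. "The series", "measured", "known", "first", "only" and "open" are said of these compounds alone.

Of the compounds shown here, three with a shared core have been measured in a functional assay on HepG2 cells (Homo sapiens) for cytotoxicity, read by MTT assay, with a stated time of 48 h; on this read-out higher numbers stand for weaker inhibition and lower numbers for stronger inhibition. Compound 1 `COc1cc(/C=C/C(=O)/C=C/c2nc3c(C)cccc3n2C)ccc1O` gives 1900 nM, compound 2 `COc1cc(/C=C/C(=O)/C=C/c2nc3c(C)c(C)ccc3n2C)ccc1O` gives 8500 nM, and compound 3 `COc1ccc2c(c1)nc(/C=C/C(=O)/C=C/c1ccc(O)c(OC)c1)n2C` gives 3800 nM. The numbers for compound 3 and compound 1 cannot be told apart within the usual scatter, while the number for compound 2 is higher than both, beyond that scatter.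

Compound 4 `COc1cc(/C=C/C(=O)/C=C/c2nc3cc(O)ccc3n2C)ccc1O` differs from compound 3 by one change, methoxy to hydroxy: hydrogen in place of methyl on an oxygen on an aromatic ring. This places hydrogen in place of methyl on an oxygen on an aromatic ring.

Going by the values given here, only one measured step offers any guide, a 4.5-fold higher number from compound 1 to compound 2 (0.65 log units; beyond the scatter). That step also swaps a methyl and a hydrogen, but on an aromatic carbon rather than an oxygen, and in the opposite sense, since there the methyl arrives. Among the compounds with values here, it therefore bears on the new change only weakly, and no measured pair shows the change from methoxy to hydroxy itself. With no firm direction to go on, the estimated change is a 1.1-fold lower number from compound 3 to compound 4 (0.04 log units; within the scatter), an expected step no larger than the scatter. For compound 4 the estimate in this assay is 3500 nM, with the expected range running from 1300 nM to 9500 nM.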

Compound 4, half-maximal inhibitory concentration: 3600 nM
For compound 4 the middle estimate is 1.0-fold (0.01 log units) below the measured one; measured number inside the range.
By their numbers in this assay, from the lowest: compounds 1, 4 and 3 (each within the scatter of the next); then compound 2.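

Removing the methyl from this oxygen on an aromatic ring, so that methoxy becomes hydroxy, gives a 1.1-fold lower number from compound 3 to compound 4 (0.02 log units; within the scatter) in this assay, and the two compounds cannot be told apart. Going by these compounds alone, this is the first measured pair for this change, and it shows that on this core, in this cell read-out, the methyl on the oxygen can be replaced by hydrogen without a change that rises above the scatter. Within the data shown here, the only other single-place step, a 4.5-fold higher number from compound 1 to compound 2 (0.65 log units; beyond the scatter), lies beyond the scatter, but it involves a methyl on an aromatic carbon in a different compound pair, so the two steps show only that not every swap of methyl and hydrogen on this core has the same outcome, and no available evidence explains the result for compound 4.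

Going by these compounds, whether this oxygen would accept something larger, such as an ethyl group or a longer chain, or whether an amine could stand in place of the hydroxy, remains open. A single pair also leaves open whether methoxy to hydroxy would give a similarly small step elsewhere on the shared core.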